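The source may report more compounds than this note shows. Statements on the series, on what has been measured and on what is new or still open speak of the compounds shown alone.

In a functional assay on the whole organism for antagonist activity, with Mus musculus as the target (a higher number here means that more compound is needed for the effect, a lower number that less compound is needed), compound 3 (`CCC(=O)NCC(=O)N(C)c1ccc(Cl)cc1C(=O)c1ccccc1Cl`) gives 1.4 mg/kg and sits within the scatter of compound 1 (`CCCCCC(=O)NCC(=O)N(C)c1ccc(Cl)cc1C(=O)c1ccccc1Cl`), which gives 1.9 mg/kg in the same test. Both stand well apart from compound 2 (`CN1CCN(CC(=O)NCC(=O)N(C)c2ccc(Cl)cc2C(=O)c2ccccc2Cl)CC1`), which gives 59 mg/kg on this scale, as a 42-fold lower number from compound 2 to compound 3 (1.62 log units; beyond the scatter) makes clear. Compound 4 (`CCCC(=O)NCC(=O)N(C)c1ccc(Cl)cc1C(=O)c1ccccc1Cl`) differs from compound 3 by a single change (methyl in place of hydrogen on a saturated chain carbon, two bonds along the chain from a carbonyl carbon): methyl in place of hydrogen on a saturated chain carbon, two bonds along the chain from a carbonyl carbon. The measured step at that same place, hydrogen in place of propyl, came to a 1.4-fold lower number from compound 1 to compound 3 (0.13 log units; within the scatter) and is the closest guide. The large steps, such as a 31-fold higher number from compound 1 to compound 2 (1.49 log units; beyond the scatter) with its 4-methylpiperazin-1-yl group, involve a different kind of replacement and bear little on this one. The expected step in this assay is therefore none beyond the scatter, an estimated 1.1-fold higher number from compound 3 to compound 4 (0.06 log units; within the scatter) in all. For compound 4 the estimate is 1.6 mg/kg with an expected range from 0.8 mg/kg to 3.2 mg/kg in this test.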

Compound 4, dose for half-maximal effect: 0.98 mg/kg
Compound 4: middle estimate off by 1.6-fold (0.21 log units), on the high side; measured number inside the range.
By their numbers in this assay, from the lowest: compounds 4, 3 and 1 (each within the scatter of the next); then compound 2.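

In this assay, methyl in place of hydrogen at this place stays within the scatter (a 1.4-fold lower number from compound 3 to compound 4 (0.15 log units; within the scatter)), and so does hydrogen in place of ethyl, three bonds along the chain from a carbonyl carbon (a 1.9-fold lower number from compound 1 to compound 4 (0.29 log units; within the scatter)), so compound 4 adds a third chain length that cannot be separated from compound 3 or compound 1. Ethyl in place of 4-methylpiperazin-1-yl, by contrast, gives a large step (a 60-fold lower number from compound 2 to compound 4 (1.78 log units; beyond the scatter)), which sets compound 2 apart from compound 4 as it did from the other two chain compounds. Nothing given here accounts for either finding.

The compounds shown leave open whether a longer chain would also stay within the scatter. They also leave open whether a simple amine such as dimethylamino at this place would bring a step as large as that of 4-methylpiperazin-1-yl.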